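The source may hold more compounds than are shown below. What is called first, only, known or untested is meant among the compounds shown, and "the series" means these compounds.

Compound 1 `CCCn1nc(C(=O)N[C@H]2COc3ccccc3N(C)C2=S)nc1Cc1ccccc1` — in a toxicity assay on HT-29 cells (Homo sapiens) for cytotoxicity (a lower number here means that less compound is tolerated, a higher number that more compound is tolerated), compound 1 gives > 100000 nM, which is a limit of the assay rather than a number.
Compound 2 `CN1C(=S)[C@@H](NC(=O)c2nc(Cc3ccccc3)n(CCCC(F)(F)F)n2)COc2ccccc21` — in this assay compound 2 gives > 100000 nM, again a limit.
Compound 3 `CN1C(=S)[C@@H](NC(=O)c2nc(Cc3ccccc3)n(C3CCOC3)n2)COc2ccccc21` — in this assay compound 3 gives > 100000 nM, also a limit.

Compound 3 therefore stands at the upper limit of this assay, and the same holds for the other two measured compounds (the limit of > 100000 nM in this assay, at which 3 of the 3 values shown sit). Among the measured steps, a step that the two limits leave unreadable from compound 1 to compound 2, a step that the two limits leave unreadable from compound 1 to compound 3 and a step that the two limits leave unreadable from compound 2 to compound 3 are all unreadable, since both ends of each step sit at the limit, so none of them gives a readable size.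

Compound 4 `Cc1cnc(-n2nc(C(=O)N[C@H]3COc4ccccc4N(C)C3=S)nc2Cc2ccccc2)nc1` differs from compound 3 by 5-methylpyrimidin-2-yl in place of oxolan-3-yl on an aromatic nitrogen. Among the measured compounds shown here, none of the measured steps touches a change of this kind, and no measured step bears on it directly. What the three measured compounds do show is that every variation of the group on the aromatic nitrogen tried so far has left the read-out at the limit. The step from compound 3 to compound 4 is accordingly expected to be a step that the limit leaves unreadable from compound 3 to compound 4, with the outcome most likely to be another limit. Compound 4 is estimated to give 150000 nM in this assay, within a range from 60000 nM to 400000 nM.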

Compound 4, half-maximal cytotoxic concentration: > 100000 nM
Compound 4: no number, only a limit; the forecaster's own chance of this, stated with the estimate: 85%; the middle value is on the limit's open side.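

Compound 4 joins compounds 1, 2 and 3 at the limit in this assay, so no step among these four compounds can be read: the limit of > 100000 nM in this assay, at which 4 of the 4 values shown sit.

What the compounds shown leave open is how far the read-out lies beyond that limit for any of them, and whether any group on the aromatic nitrogen would bring a number within range.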